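A few compounds are considered here, and "the series" means these few. Any claim that something is new, unique, unknown or untested is made for them only; others in the source may bear on it.

Working notes on the series. Within the data shown here, compound 2 `O=C(/C=C/c1ccccc1)c1nc2ccccc2[nH]1` stands with the lowest of the two numbers so far: in a functional assay on HepG2 cells (Homo sapiens) for antiproliferative activity, read by MTT assay, with a stated time of 48 h (on this read-out lower numbers stand for stronger inhibition and higher numbers for weaker inhibition), compound 2 gives 6300 nM. Among the measured compounds shown here, its nearest neighbour is compound 1 `O=C(/C=C/c1ccccc1Br)c1nc2ccccc2[nH]1`, which in this assay gives 29200 nM; the single step between them, a 4.6-fold lower number from compound 1 to compound 2 (0.67 log units; beyond the scatter), is a modest one.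

Compound 3 `Cc1ccccc1/C=C/C(=O)c1nc2ccccc2[nH]1` is not yet measured. It differs from compound 2 by methyl in place of hydrogen on an aromatic carbon, at the same place on the ring where compound 1 carries its bromo. For the measured compounds named here, the only step that bears on this change is a 4.6-fold lower number from compound 1 to compound 2 (0.67 log units; beyond the scatter), which shows that a substituent at that place raised the number. A methyl is a different group, so the step is expected to be in the same direction but smaller, because a 4.6-fold lower number from compound 1 to compound 2 (0.67 log units; beyond the scatter) was itself only modest. For compound 3 the expected step is therefore a 1.9-fold higher number from compound 2 to compound 3 (0.28 log units; within the scatter). Compound 3 is estimated at 12000 nM, with a range of 5000 nM to 30000 nM.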

Compound 3, half-maximal inhibitory concentration: 6710 nM
Compound 3: the middle estimate sits 1.8-fold (0.25 log units) above what was measured; measured number inside the range.
By their numbers in this assay, from the lowest: compounds 2 and 3 (each within the scatter of the next); then compound 1.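

In this assay, methyl in place of hydrogen on an aromatic carbon, ortho to a large group, brings no change beyond the scatter (a 1.1-fold higher number from compound 2 to compound 3 (0.03 log units; within the scatter)), so compound 2 and compound 3 stand level. Compound 1 alone suggested that a substituent at this place raises the number, but that does not hold for methyl: the bromo of compound 1 goes with the higher number, and exchanging it for methyl gives a modest step (a 4.4-fold lower number from compound 1 to compound 3 (0.64 log units; beyond the scatter)). Nothing measured on these compounds accounts for the different outcomes with the two groups.

As far as these compounds go, with only bromo and methyl at this place, it remains open how a chloro, a methoxy or an amine would fall relative to these values. Also open, from the compounds shown here alone, is whether methyl or bromo would give the same outcome elsewhere on the same ring.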